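This account rests on a few compounds, and the source may have more. Where it says the series, first, only, none or still open, it means among the compounds named here.

Measured compounds:
- compound 1, `CCCCCCCCCCCCCCCCCCNC(=O)[C@H]1CSC(c2c[nH]c3ccccc23)N1`: 11500 nM
- compound 2, `CCCCCCCCCCCCCCCCCCNC(=O)[C@H]1CSC(c2cccnc2)N1`: 9200 nM
- compound 3, `CCCCCCCCCCCCCCCCCCNC(=O)[C@H]1CSC(c2ccc([N+](=O)[O-])cc2)N1`: about 20000 nM

Of the compounds shown here, three sharing one core have been measured in a functional assay on PC-3 cells (Homo sapiens) for antiproliferative activity, read by sulforhodamine B assay; on this read-out higher numbers stand for weaker inhibition and lower numbers for stronger inhibition. Compound 1 stands second highest of the three numbers: its nearest neighbour is compound 2, with a 1.3-fold lower number from compound 1 to compound 2 (0.10 log units; within the scatter), and its furthest is compound 3, with a 1.7-fold higher number from compound 1 to compound 3 (0.24 log units; within the scatter); neither step lies beyond the scatter. Going by the values given here, the only step that does is a 2.2-fold higher number from compound 2 to compound 3 (0.34 log units; beyond the scatter), and it is modest.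

Compound 4, `CCCCCCCCCCCCCCCCCCNC(=O)[C@H]1CSC(c2ccc(C#N)cc2)N1`, is not yet measured. It differs from compound 1 in one place: 4-cyanophenyl in place of 1H-indol-3-yl on a saturated ring carbon. Among the compounds with values here, the steps that bear on this are the two other exchanges of the aryl group on the same saturated ring carbon, from compound 1 to compound 2 and from compound 1 to compound 3, both within the scatter, and the modest step from compound 2 to compound 3. On that basis the account expects at most a small rise in the number, probably not beyond the scatter, giving an expected 1.3-fold higher number from compound 1 to compound 4 (0.12 log units; within the scatter). Compound 4 is therefore estimated at 15000 nM, with a range from 7000 nM to 35000 nM.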

Compound 4, half-maximal inhibitory concentration: > 20000 nM
Compound 4: only a limit was reported; the forecaster's own chance of this, stated with the estimate: 10%; middle value at least 1.3-fold (0.12 log units) from the limit.
By their numbers in this assay, from the lowest: compounds 2, 1 and 3 (each within the scatter of the next, the first and the last beyond it).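

In this assay compound 4 gives > 20000 nM, which is a limit of the assay and not a number. Even so, the step to 4-cyanophenyl can be read in part: an at least 2.1-fold higher number from compound 2 to compound 4 (0.33 log units; beyond the scatter) joins a 2.2-fold higher number from compound 2 to compound 3 (0.34 log units; beyond the scatter), so two groups at this saturated ring carbon, 4-cyanophenyl and 4-nitrophenyl, now stand beyond the scatter from pyridin-3-yl, whereas the earlier compounds gave only one such step, while an at least 1.7-fold higher number from compound 1 to compound 4 (0.24 log units; that floor lies within the scatter) keeps the floor of the step from 1H-indol-3-yl within the scatter. The exchange of nitro for cyano on the aromatic carbon gives a number no lower from compound 3 to compound 4 (the limit leaves the size open), and neither its size nor any order between these two compounds can be read, because the value of compound 4 is a limit: the limit of > 20000 nM in this assay, at which 1 of the 4 values shown sits.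

The compounds shown leave open how far the number of compound 4 actually lies from the others, and whether an amine or a carboxylic acid at the same place on the phenyl ring would move the number in either direction. They also leave open what a shorter chain on the amide nitrogen would do, as all four compounds carry the same long chain.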